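A few compounds are considered here, and "the series" means these few. Any claim that something is new, unique, unknown or untested is made for them only; others in the source may bear on it.

Measured compounds in an assay on HEK293 cells for positive allosteric modulation of metabotropic glutamate receptor 3 (Rattus norvegicus), read by thallium flux, with a stated time of 2.5 min; a lower number here means that less compound is needed, a higher number that more compound is needed for the effect:

Compound 1, `Cc1cc(C(=O)O)ccc1OCCCCOc1ccc(C(=O)CC(C)C)c(O)c1C`, gives 1850 nM.
Compound 2, `Cc1c(OCCCCOc2ccc(C(=O)O)cc2Cl)ccc(C(=O)CC(C)C)c1O`, gives 1140 nM.
Compound 3, `Cc1cc(OCCCCOc2ccc(C(=O)CC(C)C)c(O)c2C)ccc1C(=O)O`, gives 3910 nM.

The three compounds share a core and differ in the aryl group that sits on the oxygen of the saturated chain. Compound 1 and compound 2 differ by one atom: chloro in place of methyl on an aromatic carbon. This exchange gave a 1.6-fold lower number from compound 1 to compound 2 (0.21 log units; within the scatter). Compound 1 and compound 3 carry the same atoms joined differently; the two cores differ as 4-carboxy-3-methylphenyl in place of 4-carboxy-2-methylphenyl on an oxygen on a saturated carbon. That rearrangement gave a 2.1-fold higher number from compound 1 to compound 3 (0.33 log units; beyond the scatter), and from compound 2 the same endpoint gave a 3.4-fold higher number from compound 2 to compound 3 (0.54 log units; beyond the scatter). Compound 3 thus stands with the highest of the three numbers, with both other compounds beyond the scatter from it.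

Compound 4, `Cc1c(OCCCCOc2ccc(C(=O)O)c(Cl)c2)ccc(C(=O)CC(C)C)c1O`, has not yet been measured in this assay . It relates to compound 3 as chloro in place of methyl on an aromatic carbon. Among the measured compounds shown here, this is the same kind of change as the one from compound 1 to compound 2, but not the same: in that earlier pair the chloro sat ortho to a large group and meta to a carboxy group, whereas here it sits ortho to a carboxy group and meta to a large group. Because a 1.6-fold lower number from compound 1 to compound 2 (0.21 log units; within the scatter) stayed within the scatter, the step from compound 3 to compound 4 is expected to be similarly small, about a 1.4-fold lower number from compound 3 to compound 4 (0.15 log units; within the scatter). Compound 4 is therefore estimated at 2800 nM, with an expected range from 1200 nM to 6500 nM.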

Compound 4, half-maximal effective concentration: 2050 nM
Beside the measured number, compound 4's estimate is 1.4-fold (0.14 log units) above it, within the range that was stated.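

In this assay, chloro in place of methyl on the core of compound 3, ortho to a carboxy group, gave a 1.9-fold lower number from compound 3 to compound 4 (0.28 log units; within the scatter), and the same change on the core of compound 1 agrees with it within the scatter: the same change on two cores in this assay, a 1.6-fold lower number (0.21 log units; within the scatter) from compound 1 to compound 2 and a 1.9-fold lower number (0.28 log units; within the scatter) from compound 3 to compound 4, 1.2-fold (0.07 log units) apart, within the scatter of two such steps. The other two new steps also stay within the scatter, with 4-carboxy-3-chlorophenyl in place of 4-carboxy-2-chlorophenyl giving a 1.8-fold higher number from compound 2 to compound 4 (0.25 log units; within the scatter) and 4-carboxy-3-chlorophenyl in place of 4-carboxy-2-methylphenyl giving a 1.1-fold higher number from compound 1 to compound 4 (0.04 log units; within the scatter). The exchange of methyl for chloro thus carried over between these two cores with steps of similar small size, but neither step can be told from the scatter, so this does not show that the exchange has a real effect on either core, nor that it would behave the same way on any other core.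

All four compounds keep the same saturated chain, the same ketone side group and a carboxylic acid on the aryl group, which leaves open how the numbers in this assay would respond to a longer chain or to an amide or a tetrazole in place of that acid. Also open, from the compounds shown here alone, is how fluoro or methoxy at the same aromatic carbon would compare with chloro and methyl.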